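The compounds below may be only part of what the source reports. "The series", "measured", "known", "first", "only" and "open" are said of these compounds alone.

Compounds measured so far in a functional assay on the whole organism for inhibition, with Rattus norvegicus as the target, read by paw edema, at a dose of 100 mg/kg by the oral route; a lower number here means less inhibition, a higher number more inhibition at the dose given (going by the name of the read-out):
compound 1, `O=C(Nc1ccccn1)c1c(O)c2cccnc2n(-c2ccccc2)c1=O`, -13.5%
compound 2, `CN(C)CCNC(=O)c1c(O)c2cccnc2n(-c2ccccc2)c1=O`, 22.6%
compound 3, `Cc1cccc(NC(=O)c2c(O)c3cccnc3n(-c3ccccc3)c2=O)c1`, 14.2%

Compound 2 gives the highest number of the three, yet its distance to compound 3 is only a number 8.4 percentage points lower from compound 2 to compound 3 (within the scatter), so the two cannot be told apart; only compound 1 lies clearly apart, as a number 36.1 percentage points higher from compound 1 to compound 2 (beyond the scatter) shows.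

Compound 4, `O=C(Nc1ccc(Cl)nc1)c1c(O)c2cccnc2n(-c2ccccc2)c1=O`, has not been measured. It differs from compound 2 in one place: 6-chloropyridin-3-yl in place of 2-(dimethylamino)ethyl on an amide-type nitrogen.

Among the measured compounds shown here, two measured steps bear on this change. The step from a pyridin-2-yl to the 2-(dimethylamino)ethyl chain brought a number 36.1 percentage points higher from compound 1 to compound 2 (beyond the scatter), a large rise, so removing that chain in favour of an aromatic ring is the reverse of a move that helped. The step from the chain to a 3-methylphenyl gave a number 8.4 percentage points lower from compound 2 to compound 3 (within the scatter), no real change. Compound 4 carries a pyridinyl ring bearing a chlorine, which resembles the ring of compound 1 more than the ring of compound 3; on that ground a drop beyond the scatter is expected, of about a number 22.6 percentage points lower from compound 2 to compound 4 (beyond the scatter). Compound 4 is accordingly estimated at 0%, within a range from -20% to 20%.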

Compound 4, a percentage reported as inhibition, in the whole organism at one dose (the size of the read-out at that dose, not a potency): 9.2%
Compound 4: the middle estimate sits 9.2 percentage points below what was measured, and the stated range covers the measured number.
By their numbers in this assay, from the lowest: compound 1; then compounds 4, 3 and 2 (each within the scatter of the next, the first and the last beyond it).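

In this assay, exchanging pyridin-2-yl for 6-chloropyridin-3-yl on the amide-type nitrogen gives a number 22.7 percentage points higher from compound 1 to compound 4 (beyond the scatter) and so shows that a six-membered aromatic ring with one hetero atom at this place does not by itself bring the low number of the pyridin-2-yl amide. Replacing 2-(dimethylamino)ethyl with the same ring gives a number 13.4 percentage points lower from compound 2 to compound 4 (beyond the scatter) and so separates the chain from this ring, which the 3-methylphenyl group did not do. The two aromatic groups themselves remain unresolved, with a number 5 percentage points lower from compound 3 to compound 4 (within the scatter) for the exchange of one for the other, so the 6-chloropyridin-3-yl and 3-methylphenyl groups cannot be told apart at this position.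

The compounds shown do not separate the part played by the chlorine from that of where the ring is attached, a question that the unsubstituted pyridin-3-yl group would address. They also leave open whether the chain result depends on its length or on its terminal amine, which 3-(dimethylamino)propyl or a 2-(morpholin-4-yl)ethyl chain would test.

Nothing available here accounts for any of these differences.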